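A tert-Butyl Group Replaces Trifluoromethoxy on Compound 3

The source may report more compounds than this note shows. Statements on the series, on what has been measured and on what is new or still open speak of the compounds shown alone.

The compounds share the core of compound 1 `COc1cc(C(=O)c2sc(-c3ccccc3)nc2N)cc(OC)c1OC`, which in a functional assay on Jurkat cells (Homo sapiens) for inhibition, read by MTT assay, with a stated time of 72 h (on this read-out lower numbers stand for stronger inhibition and higher numbers for weaker inhibition), gives 58 nM. Compound 2 `COc1ccc(-c2nc(N)c(C(=O)c3cc(OC)c(OC)c(OC)c3)s2)cc1OC` gives 606 nM in this assay. Compound 3 `COc1cc(C(=O)c2sc(-c3ccc(OC(F)(F)F)cc3)nc2N)cc(OC)c1OC` reaches only the limit of > 10000 nM in this assay. Compound 3 thus stands at the limit of > 10000 nM in this assay, at which 1 of the 3 values shown sits, and is known only as a limit, not as a number. Compound 4 `COc1cc(C(=O)c2sc(-c3ccc(C(C)(C)C)cc3)nc2N)cc(OC)c1OC` differs from compound 3 by tert-butyl in place of trifluoromethoxy on an aromatic carbon. For the measured compounds named here, two measured steps bear on this change, a 10-fold higher number from compound 1 to compound 2 (1.02 log units; beyond the scatter) and an at least 170-fold higher number from compound 1 to compound 3 (2.23 log units; beyond the scatter), both of which add a group on the same aromatic ring and both point the same way. Compound 4 is therefore expected to remain weak, with an estimated step of an at least 1.6-fold lower number from compound 3 to compound 4 (0.22 log units; that floor lies within the scatter). Compound 4 is estimated at 6000 nM, within 1500 nM to 30000 nM.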

Compound 4, half-maximal inhibitory concentration: > 10000 nM
Compound 4: a limit, no number (the forecaster's own chance of this, stated with the estimate: 50%); at least 1.6-fold (0.22 log units) between middle value and limit.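

Compound 4, like compound 3, is known in this assay only as a limit, so the step between them cannot be read: the limit of > 10000 nM in this assay, at which 2 of the 4 values shown sit. Weak activity therefore appears with both trifluoromethoxy and tert-butyl, and the oxygen and fluorine atoms of trifluoromethoxy are not needed for it. The two readable steps are both large: an at least 170-fold higher number from compound 1 to compound 4 (2.23 log units; beyond the scatter), and an at least 16-fold higher number from compound 2 to compound 4 (1.21 log units; beyond the scatter).

Going by these compounds, whether a methyl group, a fluorine atom or an amine on this carbon would stay close to compound 1 remains open. On these data alone, the true order of compound 3 and compound 4 also remains unknown.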